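The compounds below may be only part of what the source reports. "The series", "measured", "known", "first", "only" and "open" are said of these compounds alone.

Measured compounds in an assay on a protein complex for inhibition of NEDD8 activating enzyme (Homo sapiens), read by HTRF, with a stated time of 2 h, in the presence of a further agent that is not named here; on this read-out higher numbers stand for weaker inhibition and lower numbers for stronger inhibition:
compound 1 `NS(=O)(=O)OC[C@@H]1C[C@@H](n2nnc3c(N[C@H]4CCc5ccccc54)ncnc32)C[C@@H]1O` gives 0.21 nM
compound 2 `NS(=O)(=O)OC[C@@H]1C[C@@H](n2nnc3c(N[C@@H]4c5ccccc5C[C@@H]4O)ncnc32)C[C@@H]1O` gives 2.28 nM
compound 3 `CN(C)[C@H]1Cc2ccccc2[C@H]1Nc1ncnc2c1nnn2[C@@H]1C[C@@H](COS(N)(=O)=O)[C@@H](O)C1` gives 207 nM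

Compound 3 stands at the highest number of the three, with compound 2 the nearest and compound 1 the furthest. Compound 4 `COCCO[C@H]1Cc2ccccc2[C@H]1Nc1ncnc2c1nnn2[C@@H]1C[C@@H](COS(N)(=O)=O)[C@@H](O)C1` has not yet been measured in this assay. It differs from compound 3 by 2-methoxyethoxy in place of dimethylamino on a saturated ring carbon, the change sitting on a saturated ring carbon of a five-membered non-aromatic ring of carbon only, part of a fused or bridged system of two rings.

Going by the values given here, three measured steps bear on this position. The step of a 990-fold higher number from compound 1 to compound 3 (2.99 log units; beyond the scatter) and the step of a 91-fold higher number from compound 2 to compound 3 (1.96 log units; beyond the scatter) both show the dimethylamino group at the high end of the series, while the step of an 11-fold higher number from compound 1 to compound 2 (1.04 log units; beyond the scatter) shows that an oxygen-linked group at this carbon also raises the number, but by much less. Since the 2-methoxyethoxy group is oxygen-linked like the hydroxy of compound 2, compound 4 is expected to land between compound 2 and compound 3, a step of a 6.9-fold lower number from compound 3 to compound 4 (0.84 log units; beyond the scatter) toward a lower number. The estimate for compound 4 is 30 nM, with a range from 5 nM to 200 nM.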

Compound 4, half-maximal inhibitory concentration: 3.56 nM
For compound 4 the middle estimate is 8.4-fold (0.93 log units) above the measured one; the whole stated range lies above it.
By their numbers in this assay, from the lowest: compound 1; then compounds 2 and 4 (each within the scatter of the next); then compound 3.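

In this assay, 2-methoxyethoxy in place of dimethylamino on this saturated ring carbon gives a large step (a 58-fold lower number from compound 3 to compound 4 (1.76 log units; beyond the scatter)), so the high number of compound 3 does not extend to every group of this size at this carbon. The two oxygen-linked groups cannot be told apart (a 1.6-fold higher number from compound 2 to compound 4 (0.19 log units; within the scatter)), which shows that 2-methoxyethyl in place of hydrogen on that oxygen is accommodated without a step beyond the scatter. Even so, hydrogen at this carbon still gives the lowest number of the series, and 2-methoxyethoxy in its place gives a large step (a 17-fold higher number from compound 1 to compound 4 (1.23 log units; beyond the scatter)).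

No measurement shown here explains why the dimethylamino compound stands apart from the others. Going by these compounds, whether a primary amine, a carboxylic acid or a longer ether chain at this carbon would sit with compound 2 and compound 4 or with compound 3 remains open.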